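This account rests on a few compounds, and the source may have more. Where it says the series, first, only, none or still open, it means among the compounds named here.

In an assay on CHO cells for displacement of a labelled ligand from histamine receptor H3 (Macaca mulatta), read by scintillation counting, with a stated time of 1 h (on this read-out lower numbers stand for stronger inhibition and higher numbers for weaker inhibition), compound 1 `CC(=O)N1CCN(C(=O)Nc2ccc(N3CCC(N4CCCC4C)C3)cc2)CC1` gives 34.1 nM, compound 2 `CC(=O)N1CCN(C(=O)Nc2ccc(N3CCC(N4CCCC4C)C3)c(C)c2)CC1` gives 23 nM, and compound 3 `CC1CCCN1C1CCN(c2ccc(NC(=O)N3CCCCC3)cc2)C1` gives 6 nM. Compound 2 thus holds the second highest of the three numbers: it lies within the scatter of compound 1 and beyond the scatter from compound 3. Compound 4 `Cc1cc(NC(=O)NCc2cccs2)ccc1N1CCC(N2CCCC2C)C1` differs from compound 2 by ((thiophen-2-yl)methyl)amino in place of 4-acetylpiperazin-1-yl on a carbonyl carbon. For the measured compounds named here, one measured step touches the same place and removes the same group: a 5.7-fold lower number from compound 1 to compound 3 (0.75 log units; beyond the scatter). The group entering in compound 4 is a different one, so that step is only a loose guide, but a lower number is expected, and the step of a 2.9-fold lower number from compound 2 to compound 4 (0.46 log units; beyond the scatter) is the estimated outcome. For compound 4 the estimate is 8 nM, with a range from 2.5 nM to 30 nM.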

Compound 4, inhibition constant: 8.4 nM
Beside the measured number, compound 4's estimate is 1.1-fold (0.02 log units) below it; measured number inside the range.
By their numbers in this assay, from the lowest: compounds 3 and 4 (each within the scatter of the next); then compounds 2 and 1 (each within the scatter of the next).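

Replacing 4-acetylpiperazin-1-yl on the carbonyl carbon with ((thiophen-2-yl)methyl)amino gives a 2.7-fold lower number from compound 2 to compound 4 (0.44 log units; beyond the scatter). Until now, only piperidin-1-yl had shown such a drop at this place, so the gain is not tied to that one group: it also appears with an aromatic ring and an added hydrogen-bond donor, and on the methyl-bearing compound. Nothing available explains why the number falls. Still open, from the compounds shown here alone, is whether the thiophene ring matters, which a benzylamino or a plain ethylamino group at the same place could test.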